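Benzylsulfanyl dihydropyrimidines: chlorine position and artery inhibition

The compounds below may be only part of what the source reports. "The series", "measured", "known", "first", "only" and "open" are said of these compounds alone.

Measured compounds:
compound 1 `COc1ccc(C2N=C(SCc3ccccc3Cl)NC(C)=C2C(=O)Nc2ccc(Br)cc2)cc1`: 20.6%
compound 2 `COc1ccc(C2N=C(SCc3cccc(Cl)c3)NC(C)=C2C(=O)Nc2ccc(Br)cc2)cc1`: 39.7%
compound 3 `CC1=C(C(=O)Nc2ccc([N+](=O)[O-])cc2)C(c2cccc([N+](=O)[O-])c2)N=C(SCc2ccccc2Cl)N1`: 17.5%

In a functional assay on the whole organism (artery, strain albino) with Rattus norvegicus as the target, with a stated time of 360 min, at a dose of 10 mg/kg by the oral route (on this read-out higher numbers stand for more inhibition at the one dose given (going by the name of the read-out) and lower numbers for less inhibition), compound 1 gives 20.6% and compound 2 gives 39.7%. The change between them, (3-chlorophenyl in place of 2-chlorophenyl on a saturated chain carbon bound to a sulfur), made the step of a number 19.1 percentage points higher from compound 1 to compound 2 (beyond the scatter). Compound 3 gives 17.5% in this assay; the difference between the core of compound 3 and the core of compound 1 is not broken down here, and the values of compound 3 and compound 1 lie within the scatter of each other.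

Compound 4 `CC1=C(C(=O)Nc2ccc([N+](=O)[O-])cc2)C(c2cccc([N+](=O)[O-])c2)N=C(SCc2cccc(Cl)c2)N1` is not yet measured. It differs from compound 3 by 3-chlorophenyl in place of 2-chlorophenyl on a saturated chain carbon bound to a sulfur, the same kind of change as from compound 1 to compound 2. A step of about the same size is expected for compound 4, namely a number 18.5 percentage points higher from compound 3 to compound 4 (beyond the scatter), because a number 19.1 percentage points higher from compound 1 to compound 2 (beyond the scatter) is the only shown instance of this change. For compound 4 the expected value in this assay is 36%, within 20% to 52%.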

Compound 4, a percentage reported as inhibition, in the whole organism at one dose (the size of the read-out at that dose, not a potency): 21.6%
Compound 4: middle estimate off by 14.4 percentage points, on the high side; the measured number falls inside the stated range.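

In this assay, 3-chlorophenyl in place of 2-chlorophenyl on a saturated chain carbon bound to a sulfur gives a number 4.1 percentage points higher from compound 3 to compound 4 (within the scatter), so the earlier step does not carry over at its full size from the core of compound 1 to the core of compound 3: the same change on two cores in this assay, a number 19.1 percentage points higher (beyond the scatter) from compound 1 to compound 2 and a number 4.1 percentage points higher (within the scatter) from compound 3 to compound 4, 15 percentage points apart, beyond the scatter of two such steps

The size of this step therefore depends on the core, at least across these two cores. The two cores differ in more than one place, and the data do not show which of those differences goes with the smaller step.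

Open, from the compounds shown here alone, is how a plain phenyl or a phenyl bearing a carboxylic acid would behave on that chain carbon. Also open, going by these compounds, is whether either step size would recur on a third core.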